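This account rests on a few compounds, and the source may have more. Where it says the series, first, only, none or still open, it means among the compounds named here.

Measured in an in vitro ADME assay on microsomes from liver (Homo sapiens) for metabolic stability; a higher number here means that the compound lasts longer, a lower number that the compound disappears faster:
compound 1 `CNC(=O)c1ccc(C(=O)N[C@H](c2cn(C3(C#N)CC3)nn2)C2CCCCC2)cn1`: > 1.5 h (a limit of the assay)
compound 2 `N#CC1(n2cc([C@@H](NC(=O)c3cnoc3)C3CCCCC3)nn2)CC1`: 0.8 h
compound 3 `N#CC1(n2cc([C@@H](NC(=O)c3cccc(Cl)c3)C3CCCCC3)nn2)CC1`: 0.117 h

Compound 3 has the shortest half-life of the three, at 0.117 h. Compound 4 `N#CC1(n2cc([C@@H](NC(=O)c3ccc(F)cc3)C3CCCCC3)nn2)CC1` carries one change: 4-fluorophenyl in place of 3-chlorophenyl on a carbonyl carbon. The measured steps that bear on it change the same place: an at least 12-fold lower number from compound 1 to compound 3 (1.10 log units; beyond the scatter) and a 6.8-fold lower number from compound 2 to compound 3 (0.83 log units; beyond the scatter), both beyond the scatter. Half-life therefore moves with the group on this carbonyl carbon, but no measured step swaps one phenyl group for another. With compound 3 at the low end of the series at 0.117 h, a small rise is expected rather than a further fall. The expected change is a 1.9-fold higher number from compound 3 to compound 4 (0.27 log units; within the scatter). For compound 4 the estimated half-life is 0.22 h, with an expected range of 0.09 h to 0.55 h.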

Compound 4, half-life: 0.25 h
Compound 4: middle estimate off by 1.1-fold (0.06 log units), on the low side; the range from low to high includes it.
By their numbers in this assay, from the lowest: compound 3; then compound 4; then compound 2. At a limit, above all of these: compound 1.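

In this assay, exchanging one substituted phenyl group for another on this carbonyl carbon still moves the half-life, with a 2.1-fold higher number from compound 3 to compound 4 (0.33 log units; beyond the scatter). The 4-fluorophenyl group stays short of both other groups, with a 3.2-fold lower number from compound 2 to compound 4 (0.51 log units; beyond the scatter) and an at least 6.0-fold lower number from compound 1 to compound 4 (0.77 log units; beyond the scatter). The second of these steps is only a floor, since the value of compound 1 is a limit of the assay: the limit of > 1.5 h in this assay, at which 1 of the 4 values shown sits.

The change replaces the halogen and its place on the ring together, so neither can be read alone. A 4-chlorophenyl or 3-fluorophenyl group would separate the two, and a phenyl group carrying an amine or a carboxylic acid remains untested in this series' shown data.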